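The source may report more compounds than this note shows. Statements on the series, on what has been measured and on what is new or still open speak of the compounds shown alone.

Three members of the series have a measured value in an ADME assay on microsomes from liver (Rattus norvegicus) for metabolic stability, read by LC-MS, with a stated time of 30 min, tested at 0.5 uM; on this read-out higher numbers stand for a more stable compound and lower numbers for a less stable compound. Compound 1, `Oc1ccc(-c2nc(-c3csc(N=C4NCCCN4)n3)cs2)cc1`, gives 53%. Compound 2, `Oc1cccc(-c2nc(-c3csc(N=C4NCCCN4)n3)cs2)c1`, gives 35%. Compound 3, `CS(=O)(=O)c1ccc(-c2nc(-c3csc(N=C4NCCCN4)n3)cs2)cc1`, gives 53%. Compound 2 stands lowest of the three; the other two lie within the scatter of each other.

The cores of compound 1 and compound 2 differ as follows: 3-hydroxyphenyl in place of 4-hydroxyphenyl on an aromatic carbon. Moving from compound 1 to compound 2 brought a number 18 percentage points lower from compound 1 to compound 2 (beyond the scatter).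

The change of interest is methylsulfonyl in place of hydroxy on an aromatic carbon, and in this assay it made no change at the digits printed from compound 1 to compound 3 (within the scatter). The same kind of change is now to be made on the core of compound 2, giving compound 4, `CS(=O)(=O)c1cccc(-c2nc(-c3csc(N=C4NCCCN4)n3)cs2)c1`. Compound 4 differs from compound 2 as follows: methylsulfonyl in place of hydroxy on an aromatic carbon. The two place descriptions are not the same word for word: in the step from compound 1 to compound 3 the exchanged group sits para to a large group, whereas in compound 4 it sits meta to a large group, so the change is of the same kind rather than identical.

With only a single measured occurrence of the exchange, and that one within the scatter, the expectation is that the step from compound 2 to compound 4 in this assay is also small, no change at the digits printed from compound 2 to compound 4 (within the scatter), resting on the step from compound 1 to compound 3 being no change at the digits printed from compound 1 to compound 3 (within the scatter). Compound 4 is accordingly estimated at 35%, with a range from 20% to 55%.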

Compound 4, percent of the compound remaining: 47%
Estimate against measurement, compound 4: 12 percentage points below; low and high end bracket the measured number.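

In this assay, methylsulfonyl in place of hydroxy, meta to a large group on the core of compound 2, gives a number 12 percentage points higher from compound 2 to compound 4 (beyond the scatter). Set beside the same exchange on the core of compound 1, this step cannot be told apart from the earlier one, even though only the new step lies beyond the scatter when read alone: the same change on two cores in this assay, no change at the digits printed (within the scatter) from compound 1 to compound 3 and a number 12 percentage points higher (beyond the scatter) from compound 2 to compound 4, 12 percentage points apart, within the scatter of two such steps The pair is therefore compatible with the exchange carrying over between these two cores, but two occurrences do not establish that it transfers across the series, and they do not settle whether the exchange truly has a larger effect on the core of compound 2 or what size a shared effect would have.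

The compounds shown leave open whether the step would hold on a third core, and whether any result seen here extends beyond this one read-out. They also leave open how an amine or a carboxylic acid would compare with hydroxy and methylsulfonyl at the same place on either core.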